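From 2-methylphenyl to 3-fluorophenyl in a cytotoxicity series

The compounds below may be only part of what the source reports. "The series", "measured", "known", "first", "only" and "open" are said of these compounds alone.

Of the compounds shown here, two built on a shared core have been tested so far, and the question here is how a third might compare. In a functional assay on HL-60 cells (Homo sapiens) for cytotoxicity, read by WST assay, with a stated time of 48 h (on this read-out lower numbers stand for an effect already at smaller amounts and higher numbers for an effect only at larger amounts of compound), compound 1 `CCCCCCCOc1ccccc1C[C@H]1C(=O)OC[C@@H]1Cc1ccccc1` gives 75000 nM, while compound 2 `Cc1ccccc1C[C@H]1COC(=O)[C@@H]1Cc1ccc(Cl)c(Cl)c1` gives 22000 nM. Compound 2 therefore has the lower of the two numbers, and the gap between them lies beyond the usual scatter of repeated measurements.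

Compound 3 `O=C1OC[C@H](Cc2cccc(F)c2)[C@H]1Cc1ccc(Cl)c(Cl)c1` has not yet been measured. It differs from compound 2 in one place, with 3-fluorophenyl in place of 2-methylphenyl on a saturated chain carbon bound to a saturated ring carbon. The other half of the molecule stays the same.

Among the measured compounds shown here, no measured pair of compounds isolates this exchange, so the data offer no direction for it. The closest measured relative remains compound 2 at 22000 nM. In this assay, the expected change is small and within the scatter, with an estimated step of a 1.1-fold higher number from compound 2 to compound 3 (0.06 log units; within the scatter). For compound 3, the estimated value is 25000 nM, with an expected range from 9000 nM to 60000 nM.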

Compound 3, half-maximal effective concentration: 14000 nM
Compound 3: the middle estimate sits 1.8-fold (0.25 log units) above what was measured, and the stated range covers the measured number.
By their numbers in this assay, from the lowest: compounds 3 and 2 (each within the scatter of the next); then compound 1.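

In this assay, among the compounds shown here, exchanging 2-methylphenyl for 3-fluorophenyl on a saturated chain carbon bound to a saturated ring carbon gives a 1.6-fold lower number from compound 2 to compound 3 (0.20 log units; within the scatter) and so provides the first direct reading of this position. Compound 2 and compound 3 therefore cannot be told apart on this read-out, even though an all-carbon group of seven heavy atoms has given way to one of the same size that contains a fluorine. No separate measurement is available that would help to interpret this result.

For the compounds shown here, this is a single pair, so it shows only that these two aromatic groups read alike with this other half of the molecule in place, and not that the position tolerates change in general. From the compounds shown here alone, it remains open how an amine, a carboxylic acid or a longer chain would read in the same place, and whether 2-methylphenyl and 3-fluorophenyl would still match if the other half of the molecule were different.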